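From 2-fluorophenyl to 3-chlorophenyl on an amide-type nitrogen

This account rests on a few compounds, and the source may have more. Where it says the series, first, only, none or still open, it means among the compounds named here.

Measured so far in a functional assay on NCI-H460 cells (Homo sapiens) for inhibition, read by CCK-8 assay, with a stated time of 72 h, tested at 10 uM; on this read-out higher numbers stand for more inhibition of growth at the one concentration tested and lower numbers for less inhibition of growth

compound 1 `CN(C)C(=O)c1cc2cnc(Nc3ccc(NC(=O)C4(C(=O)Nc5ccc(F)cc5)CC4)cc3)nc2n1C1CCCC1` gives 102%
compound 2 `CN(C)C(=O)c1cc2cnc(Nc3ccc(NC(=O)C4(C(=O)Nc5ccccc5F)CC4)cc3)nc2n1C1CCCC1` gives 93.1%

Among the measured compounds shown here, compound 2 lies within the scatter of compound 1, the only other measured compound. Compound 3 `CN(C)C(=O)c1cc2cnc(Nc3ccc(NC(=O)C4(C(=O)Nc5cccc(Cl)c5)CC4)cc3)nc2n1C1CCCC1` is still unmeasured, and it differs from compound 2 as follows: 3-chlorophenyl in place of 2-fluorophenyl on an amide-type nitrogen. For the measured compounds named here, the one measured step that bears on this, 2-fluorophenyl in place of 4-fluorophenyl, is a number 8.9 percentage points lower from compound 1 to compound 2 (within the scatter). Going by the values given here, no measured compound carries 3-chlorophenyl, so this is weak guidance, and no shift beyond the scatter is expected. The expected change is a number 0.1 percentage points lower from compound 2 to compound 3 (within the scatter). Compound 3 is estimated at 93%, with an expected range of 76% to 106%.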

Compound 3, percent growth inhibition at one concentration: 101%
For compound 3 the middle estimate is 8 percentage points below the measured one; the measured number falls inside the stated range.
By their numbers in this assay, from the lowest: compounds 2, 3 and 1 (each within the scatter of the next).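

In this assay, the change to 3-chlorophenyl on the amide-type nitrogen gives a number 7.9 percentage points higher from compound 2 to compound 3 (within the scatter), and measured against the 4-fluorophenyl group it gives a number 1 percentage points lower from compound 1 to compound 3 (within the scatter). This position therefore accepts a chlorine-bearing phenyl as well as either fluorophenyl, with all three compounds reading alike at the one concentration tested. Nothing available explains this sameness. On these data alone, it remains open whether a carboxylic acid or an amine on this phenyl ring would keep the reading. A pyridine ring or a cyclohexyl group in place of the phenyl is equally untested here.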